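The compounds below may be only part of what the source reports. "The series", "measured", "known", "first", "only" and "open" are said of these compounds alone.

Measured so far in an ADME assay on HeLa cells (Homo sapiens) for cytotoxicity, read by resazurin assay, with a stated time of 2 days; a higher number here means a weaker inhibitor, a lower number a stronger inhibitor:
compound 1 `Cn1c([N+](=O)[O-])cnc1/C=C/c1ccccc1Br` gives 72400 nM
compound 2 `Cn1c([N+](=O)[O-])cnc1/C=C/c1ccc(Br)cc1` gives 72400 nM

In this assay compound 1 stands level with compound 2 at the digits reported, and the two values show no separation beyond the scatter. Compound 3 `Cn1c([N+](=O)[O-])cnc1/C=C/c1ccccc1I` is not yet measured. It carries the change iodo in place of bromo on an aromatic carbon on the core of compound 1: iodo in place of bromo on an aromatic carbon, ortho to a large group. Among the measured compounds shown here, the series holds no measured step of this kind to scale it against, so the expectation rests only on the structural change and on compound 1 at 72400 nM as the starting point. No shift beyond the scatter is expected in this assay and no firm direction can be given. The expected change is a 1.2-fold lower number from compound 1 to compound 3 (0.08 log units; within the scatter) as estimated here. For compound 3 the estimated value is 60000 nM with an expected range from 30000 nM to 110000 nM as the working span.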

Compound 3, half-maximal inhibitory concentration: > 100000 nM
Compound 3 was reported as a limit (the forecaster's own chance of this, stated with the estimate: 10%); middle value at least 1.6-fold (0.22 log units) away from the limit.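

Up to this point the series held bromo alone, so compound 3 gives the first reading of another halogen on this aromatic carbon, ortho to a large group. In this assay compound 3 gives > 100000 nM, which is a limit of the assay and not a number. Iodo in place of bromo gives an at least 1.3-fold higher number from compound 1 to compound 3 (0.14 log units; that floor lies within the scatter), so the change brings no sign of a lower number, and the size of any rise cannot be read: the limit of > 100000 nM in this assay, at which 1 of the 3 values shown sits.

Going by these compounds, whether compound 3 truly separates from compound 1 beyond the scatter stays open, as only the floor of the step can be read. Also open, on these data alone, is how fluoro, chloro or an amine on this same carbon would read in this assay.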